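This account rests on a few compounds, and the source may have more. Where it says the series, first, only, none or still open, it means among the compounds named here.

Measured in a functional assay on HL-60 cells (Homo sapiens) for antiproliferative activity, read by MTT assay; a higher number here means a weaker inhibitor, a lower number a stronger inhibitor:
- Compound 1 `O=C(N/N=C/c1ccccc1)c1cn(C2CC2)c2cc(N/N=C/c3ccccc3)c(F)cc2c1=O`: <= 25000 nM
- Compound 2 `O=C(N/N=C/c1ccccc1[N+](=O)[O-])c1cn(C2CC2)c2cc(N/N=C/c3ccccc3[N+](=O)[O-])c(F)cc2c1=O`: <= 25000 nM
- Compound 3 `O=C(N/N=C/c1ccccc1O)c1cn(C2CC2)c2cc(N3CCNCC3)c(F)cc2c1=O`: <= 25000 nM

Compound 3 has no exact number, only a limit. The same is true of the whole set, which comes down to the limit of <= 25000 nM in this assay, at which 3 of the 3 values shown sit. Compound 4 `O=C(N/N=C/c1ccc(F)cc1)c1cn(C2CC2)c2cc(N3CCNCC3)c(F)cc2c1=O` keeps the core of compound 3 and changes one group: 4-fluorophenyl in place of 2-hydroxyphenyl on a carbon with a double bond to nitrogen. Within the data shown here, no measured pair shows what such a swap does in this assay, so no direction can be favoured, and no change beyond the scatter is expected. That expectation rests on compound 3, whose limit is <= 25000 nM. The expected step is a step that the limit leaves unreadable from compound 3 to compound 4. For compound 4 the estimated value is 15000 nM, with an expected range of 4000 nM to 30000 nM.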

Compound 4, half-maximal inhibitory concentration: <= 25000 nM
Compound 4 gave a limit, no number (the forecaster's own chance of this, stated with the estimate: 60%); the middle value lies beyond the limit too.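

Among these compounds, compound 3 and compound 4 each give only a limit in this assay, and no step between them can be read. From the compounds shown here alone, whether 4-fluorophenyl in place of 2-hydroxyphenyl changes the activity at all remains open.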